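A few compounds are considered here, and "the series" means these few. Any claim that something is new, unique, unknown or untested is made for them only; others in the source may bear on it.

Compound 3 `COc1ccc(N/C=N/C2=C(C#N)C3C(N4CCCC4)CCCCN3C(=O)N2c2ccccc2)cc1` stands lowest of the three measured compounds in a functional assay on the whole organism (strain albino) for inhibition, with Rattus norvegicus as the target, read by paw edema, with a stated time of 1 h, at a dose of 20 mmol/kg by the intraperitoneal route (a higher number here means more inhibition at the dose given (going by the name of the read-out), a lower number less inhibition), where compound 3 gives 20.6%. Compound 1 `N#CC1=C(NCC(=O)N2CCOCC2)N(c2ccccc2)C(=O)N2CCCCC(N3CCCC3)C12` gives 43.9% and compound 2 `N#CC1=C(NCC(=O)N2CCCC2)N(c2ccccc2)C(=O)N2CCCCC(N3CCCC3)C12` gives 40.1%; the step of a number 3.8 percentage points lower from compound 1 to compound 2 (within the scatter) lies within the scatter, so these two are not told apart. For the measured compounds named here, the steps that bear on the next compound are a number 23.3 percentage points lower from compound 1 to compound 3 (beyond the scatter) and a number 19.5 percentage points lower from compound 2 to compound 3 (beyond the scatter), both modest and beyond the scatter, in each case when a group holding an aromatic ring replaced a smaller group holding a non-aromatic ring. Compound 4 `N#CC1=C(NCN2CCCCC2)N(c2ccccc2)C(=O)N2CCCCC(N3CCCC3)C12` differs from compound 3 in the opposite sense: a group of 8 heavy atoms (6 carbon, 2 nitrogen; one six-membered non-aromatic ring with 1 hetero atom) in place of a group of 11 heavy atoms (8 carbon, 2 nitrogen, 1 oxygen; one six-membered aromatic ring of carbon only), on a double-bonded ring carbon. Because the steps of a number 23.3 percentage points lower from compound 1 to compound 3 (beyond the scatter) and a number 19.5 percentage points lower from compound 2 to compound 3 (beyond the scatter) lowered the read-out when the aromatic-ring group entered, the reverse exchange is expected to regain part of that loss, an expected step of a number 15.4 percentage points higher from compound 3 to compound 4 (beyond the scatter). The entering group is not the same as those of compound 1 or compound 2, so only a partial regain is expected. Compound 4 is estimated at 36%, with a range from 22% to 50%.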

Compound 4, a percentage reported as inhibition, in the whole organism at one dose (the size of the read-out at that dose, not a potency): 29.7%
Compound 4: the middle estimate sits 6.3 percentage points above what was measured; the measured number falls inside the stated range.
By their numbers in this assay, from the lowest: compounds 3 and 4 (each within the scatter of the next); then compounds 2 and 1 (each within the scatter of the next).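

Exchanging the aromatic-ring group for ((piperidin-1-yl)methyl)amino on the double-bonded ring carbon gave a number 9.1 percentage points higher from compound 3 to compound 4 (within the scatter) in this assay, so a non-aromatic ring in this position did not by itself bring a regain that can be told apart. The step of a number 10.4 percentage points lower from compound 2 to compound 4 (beyond the scatter) and the step of a number 14.2 percentage points lower from compound 1 to compound 4 (beyond the scatter) are both modest, and they show that piperidin-1-yl on the saturated chain carbon, with no carbonyl there, stands apart from the (pyrrolidin-1-yl)carbonyl and (morpholin-4-yl)carbonyl groups. No measurement shown accounts for these steps.

Still open, on these data alone, is whether the carbonyl or the ring it carries sets the level, since the two always change together here. A (piperidin-1-yl)carbonyl group on the same chain carbon would separate the two, and an open-chain diethylamino group would test whether the piperidine ring matters at all.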